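The compounds below may be only part of what the source reports. "The series", "measured", "known", "first", "only" and "open" are said of these compounds alone.

The series is followed in a functional assay on A549 cells (Homo sapiens) for cytotoxicity, read by XTT assay, with a stated time of 24 h; a lower number here means a stronger inhibitor, a higher number a weaker inhibitor. Compound 1 `Cn1nnnc1SCC(=O)N/N=C/c1ccc(O)cc1` gives only a limit and no number, > 10000000 nM. Compound 2 `COc1ccc(/C=N/NC(=O)CSc2nnnn2C)cc1` likewise returns only a limit, > 10000000 nM. The change between them, (methyl in place of hydrogen on an oxygen on an aromatic ring), therefore leaves a step, a step that the two limits leave unreadable from compound 1 to compound 2, that two limits make unreadable. Compound 3 `Cn1nnnc1SCC(=O)N/N=C/c1ccccc1O` also stands at a limit, > 10000000 nM. Indeed every value so far sits at the same edge, as the limit of > 10000000 nM in this assay, at which 3 of the 3 values shown sit, records. How the core of compound 3 differs from the core of compound 1 is not broken down here. Compound 4 `COc1ccccc1/C=N/NC(=O)CSc1nnnn1C` has not yet been measured in this assay; it differs from compound 3 by methyl in place of hydrogen on an oxygen on an aromatic ring, which is the same change, at the same place, as that from compound 1 to compound 2. The step from compound 3 to compound 4 is expected to be small, a step that the limit leaves unreadable from compound 3 to compound 4, because the matching step that the two limits leave unreadable from compound 1 to compound 2 could not be read between two limits. Compound 4 is therefore estimated at 15000000 nM, most probably reported once more only as a limit, within a range from 5000000 nM to 60000000 nM.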

Compound 4, half-maximal inhibitory concentration: 7000000 nM
The estimate for compound 4 lay 2.1-fold (0.33 log units) above the measured number, within the range that was stated.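

In this assay, the change from hydroxy to methoxy on the core of compound 3 gives an at least 1.4-fold lower number from compound 3 to compound 4 (0.15 log units; that floor lies within the scatter), so the only thing that can be read is a floor, and this floor does not go beyond the usual scatter. The matching step on the core of compound 1 cannot be read, as both of its ends are limits, so the data show neither that the change carries over from one core to the other nor that it fails to. Compound 3 gives > 10000000 nM, which is a limit and not a number, so the full size of the step stays unknown: the limit of > 10000000 nM in this assay, at which 3 of the 4 values shown sit.

The compounds shown carry only hydroxy or methoxy on the aromatic ring, which leaves open how an amine, a carboxylic acid or a longer chain on the oxygen would read in this assay. With a number for compound 4 alone, they also leave open how the step would read on any further core.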